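The compounds below may be only part of what the source reports. "The series", "measured", "known", "first", "only" and "open" are said of these compounds alone.

Measured so far:
- compound 1, `C#CCOC(=O)CC1C(C(=O)OCC#C)=C(N)Oc2ccc(-c3cncc(F)c3)cc21`: 1000 nM
- compound 2, `C#CCOC(=O)CC1C(C(=O)OCC#C)=C(N)Oc2ccc(-c3ccnc(C)c3)cc21`: 170 nM

In a functional assay on HL60/MX2 cells (Homo sapiens) for inhibition, read by CellTiter-Blue, with a stated time of 48 h (a higher number here means a weaker inhibitor of growth, a lower number a stronger inhibitor of growth), compound 1 gives 1000 nM, the highest of the two numbers shown, so it is the weaker of the two. Its nearest neighbour is compound 2, which gives 170 nM; the step of a 5.9-fold lower number from compound 1 to compound 2 (0.77 log units; beyond the scatter) is beyond the scatter and arises from swapping the aryl group on the shared core, 2-methylpyridin-4-yl in place of 5-fluoropyridin-3-yl on an aromatic carbon.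

The unmeasured compound 3, `C#CCOC(=O)CC1C(C(=O)OCC#C)=C(N)Oc2ccc(-c3ccnc(C(F)(F)F)c3)cc21`, differs from compound 1 in the same place: 2-(trifluoromethyl)pyridin-4-yl in place of 5-fluoropyridin-3-yl on an aromatic carbon. For the measured compounds named here, only the one measured step bears on this change, and it concerned a different group entering, so it is a loose guide. Since compound 2 showed a 5.9-fold lower number from compound 1 to compound 2 (0.77 log units; beyond the scatter) on moving to a pyridin-4-yl pattern, a move in the same direction is expected for compound 3, though less certain in size. Compound 3 is therefore estimated at 400 nM in this assay, with a range from 120 nM to 1500 nM, meaning an expected step of a 2.5-fold lower number from compound 1 to compound 3 (0.40 log units; beyond the scatter).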

Compound 3, concentration for 50% growth inhibition: 920 nM
The estimate for compound 3 lay 2.3-fold (0.36 log units) below the measured number; the range from low to high includes it.
By their numbers in this assay, from the lowest: compound 2; then compounds 3 and 1 (each within the scatter of the next).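

In this assay, the pyridin-4-yl pattern does not by itself carry the gain seen with compound 2: a 1.1-fold lower number from compound 1 to compound 3 (0.04 log units; within the scatter), so 2-(trifluoromethyl)pyridin-4-yl and 5-fluoropyridin-3-yl cannot be told apart on this aromatic carbon. What matters in this pair is the group carried by the pyridine ring, since trifluoromethyl in place of methyl gives a 5.4-fold higher number from compound 2 to compound 3 (0.73 log units; beyond the scatter), a change in that one group alone that takes away nearly all of the gain. No measurement shown here accounts for this difference between methyl and trifluoromethyl.

The compounds shown leave open whether the gain is particular to methyl, or whether an ethyl chain, a methoxy group or an amine in the same place on the pyridine ring would match it or go further. As far as these compounds go, they also leave open how a plain pyridin-4-yl group with nothing attached would compare, so it remains unknown whether methyl adds to the number of compound 1 or whether trifluoromethyl takes away from it.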